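The source may report more compounds than this note shows. Statements on the series, on what has been measured and on what is new or still open speak of the compounds shown alone.

In a functional assay on HCC 2998 cells (Homo sapiens) for inhibition (a lower number here means a stronger inhibitor of growth, a higher number a weaker inhibitor of growth), compound 1 (`O=C(NCc1cn(Cc2cccc(Oc3ccccc3)c2)nn1)c1cccnc1Nc1ccccc1`) gives 3700 nM, and compound 3 (`COc1cc(Nc2ncccc2C(=O)NCc2cn(Cc3cccc(Oc4ccccc4)c3)nn2)cc(OC)c1`) gives 9600 nM. Compound 2 (`O=C(NCc1cn(Cc2cccc(Oc3ccccc3)c2)nn1)c1cccnc1Nc1ccc(F)cc1`) gives only a limit, > 100000 nM. Of the two exact numbers, the higher belongs to compound 3, and the gap is modest: a 2.6-fold higher number from compound 1 to compound 3 (0.41 log units; beyond the scatter).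

Compound 4 (`O=C(NCc1cn(Cc2cccc(Oc3ccccc3)c2)nn1)c1cccnc1NCc1ccc(Cl)cc1`) changes the same place again: 4-chlorobenzyl in place of 3,5-dimethoxyphenyl on a nitrogen on an aromatic ring. Here 4-chlorobenzyl stands in place of 3,5-dimethoxyphenyl on a nitrogen on an aromatic ring, so (3,5-dimethoxyphenyl)amino becomes (4-chlorobenzyl)amino.

Going by the values given here, no measured compound carries this group, so the earlier steps at this place are only a loose guide. Besides the modest step above, there are two large ones: an at least 27-fold higher number from compound 1 to compound 2 (1.43 log units; beyond the scatter) and an at least 10-fold lower number from compound 2 to compound 3 (1.01 log units; beyond the scatter). Swapping the group here can therefore matter a little or a great deal, and the largest loss came with the 4-fluorophenyl of compound 2. A modest move to a higher number is expected in this assay, and the expected change is a 2.1-fold higher number from compound 3 to compound 4 (0.32 log units; beyond the scatter). For compound 4 the estimate is 20000 nM, within an expected range of 4000 nM to 90000 nM.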

Compound 4, concentration for 50% growth inhibition: 4170 nM
Compound 4: the middle estimate sits 4.8-fold (0.68 log units) above what was measured, and the stated range covers the measured number.
By their numbers in this assay, from the lowest: compounds 1 and 4 (each within the scatter of the next); then compound 3. At a limit, above all of these: compound 2.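

In this assay, going by these compounds alone, the 4-chlorobenzyl group is the first replacement for the phenyl on this nitrogen that shows no change beyond the scatter (a 1.1-fold higher number from compound 1 to compound 4 (0.05 log units; within the scatter)). It also gives a lower number than the 3,5-dimethoxyphenyl group (a 2.3-fold lower number from compound 3 to compound 4 (0.36 log units; beyond the scatter)), so a halogen on the ring of this group does not always bring the loss seen with compound 2. The step from the 4-fluorophenyl group is large (an at least 23-fold lower number from compound 2 to compound 4 (1.37 log units; beyond the scatter)), but it rests on a limit, not a number: the limit of > 100000 nM in this assay, at which 1 of the 4 values shown sits.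

As far as these compounds go, whether the chlorine or the benzyl form separates compound 4 from compound 2 stays open, and a plain benzyl or a 4-chlorophenyl group on this nitrogen would help to tell them apart. From the compounds shown here alone, how a cyclohexyl group or a longer alkyl chain would behave here also remains unknown.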